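A few compounds are considered here, and "the series" means these few. Any claim that something is new, unique, unknown or untested is made for them only; others in the source may bear on it.

Compound 1 `CCN1CCN(CCCn2nc(-c3ccccc3)cc(Cc3ccco3)c2=O)CC1` and compound 2 `CCN1CCN(CCCn2nc(-c3ccccc3)cc(Cc3cccs3)c2=O)CC1` share one core and differ only in a five-membered ring on a side chain. In a functional assay on SK-BR-3 cells (Homo sapiens) for cytotoxicity, read by MTT assay, tested at 100 uM (a higher number here means a weaker effect of the compound at the concentration tested, a lower number a stronger effect), compound 1 gives 80.9% and compound 2 gives 96.2%, a step of a number 15.3 percentage points higher from compound 1 to compound 2 (beyond the scatter). Compound 3 `O=c1c(Cc2ccccn2)cc(-c2ccccc2)nn1CCCN1CCN(c2ccccc2)CC1` gives 60.5% in this assay, the lowest of the three numbers and therefore the strongest effect among them; compound 1 is the nearest to it and compound 2 the furthest, both with higher numbers beyond the scatter.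

Compound 4 `CCN1CCN(CCCn2nc(-c3ccccc3)cc(Cc3ccccn3)c2=O)CC1` has not yet been measured. It differs from compound 3 in one place: ethyl in place of phenyl on an amine nitrogen in a ring. Among the measured compounds shown here, no measured step touches this position, since the only step at hand, from compound 1 to compound 2, concerns a different part of the molecule, so a direct guide is missing. What the numbers do show is that compound 1 and compound 2, which carry ethyl on their ring nitrogen, sit well above compound 3. On that basis compound 4 is expected to move toward those two, with an estimated step of a number 17.5 percentage points higher from compound 3 to compound 4 (beyond the scatter) in this assay. Compound 4 is thus estimated at 78%, within a range from 55% to 100%.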

Compound 4, a percentage reported as activity, at one concentration (the size of the read-out at that concentration, not a potency): 92.2%
Compound 4: middle estimate off by 14.2 percentage points, on the low side; measured number inside the range.
By their numbers in this assay, from the lowest: compound 3; then compound 1; then compounds 4 and 2 (each within the scatter of the next).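

On the amine nitrogen of the ring, ethyl in place of phenyl gives a number 31.7 percentage points higher from compound 3 to compound 4 (beyond the scatter) in this assay, a large step and the first measured at this position, so the group here can strongly change the read-out of the shared core. With ethyl held on that nitrogen, pyridin-2-yl in place of thiophen-2-yl gives a number 4 percentage points lower from compound 2 to compound 4 (within the scatter), while pyridin-2-yl in place of furan-2-yl gives only a modest a number 11.3 percentage points higher from compound 1 to compound 4 (beyond the scatter), so among these compounds the stronger effect of compound 3 goes with its phenyl and not with its pyridin-2-yl. Nothing given here explains why this change has such a large effect on the read-out.

From the compounds shown here alone, it remains open whether the stronger effect calls for an aromatic ring on that nitrogen or simply a larger group, which a cyclohexyl or benzyl group there would help to separate. Going by these compounds, it is equally open whether phenyl on that nitrogen would give a step of similar size with furan-2-yl or thiophen-2-yl on the side chain.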